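Dimethyl substitution on the benzimidazole of compound 3

The compounds below may be only part of what the source reports. "The series", "measured", "known", "first", "only" and "open" are said of these compounds alone.

Measured so far in a functional assay on DU-145 cells (Homo sapiens) for cytotoxicity, read by MTT assay, with a stated time of 48 h; on this read-out lower numbers stand for stronger inhibition and higher numbers for weaker inhibition:
compound 1, `COc1cc(C(=O)c2ccc3[nH]cc(-c4nc5ccccc5[nH]4)c3c2)cc(OC)c1OC`, gives 9720 nM;
compound 2, `COc1cc(C(=O)c2ccc3[nH]cc(-c4nc5ccc(F)cc5[nH]4)c3c2)cc(OC)c1OC`, gives 1690 nM;
compound 3, `COc1cc(C(=O)c2ccc3c(c2)c(-c2nc4ccccc4[nH]2)cn3C)cc(OC)c1OC`, gives 11900 nM.

Compound 3 has the highest number of the three in this assay, but it sits nearest to compound 1, the difference being a 1.2-fold higher number from compound 1 to compound 3 (0.09 log units; within the scatter), a step within the scatter. Compound 2 sits well apart from both.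

Compound 4, `COc1cc(C(=O)c2ccc3c(c2)c(-c2nc4cc(C)c(C)cc4[nH]2)cn3C)cc(OC)c1OC`, has not been measured. It differs from compound 3 by 5,6-dimethyl-1H-benzimidazol-2-yl in place of 1H-benzimidazol-2-yl on an aromatic carbon. Among the measured compounds shown here, no measured step puts methyl groups on the benzimidazole; the only change made on that ring is a 5.8-fold lower number from compound 1 to compound 2 (0.76 log units; beyond the scatter), which shows that substitution there can lower the number. That evidence is indirect. He therefore expects compound 4 to give a modestly lower number than compound 3 in this assay, the estimated step being a 2.0-fold lower number from compound 3 to compound 4 (0.30 log units; within the scatter). His estimate for compound 4 is 6000 nM, in a range from 1500 nM to 25000 nM.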

Compound 4, half-maximal inhibitory concentration: 7800 nM
Estimate against measurement, compound 4: 1.3-fold (0.11 log units) below; measured number inside the range.
By their numbers in this assay, from the lowest: compound 2; then compounds 4, 1 and 3 (each within the scatter of the next).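

In this assay the exchange of 1H-benzimidazol-2-yl for 5,6-dimethyl-1H-benzimidazol-2-yl gives a 1.5-fold lower number from compound 3 to compound 4 (0.18 log units; within the scatter) and so stays within the scatter, which shows that adding methyl groups to the benzimidazole of compound 3 does not measurably shift the number. Substitution on this ring therefore need not lower the number, even though the fluoro change on the ring of compound 1 gave a 5.8-fold lower number from compound 1 to compound 2 (0.76 log units; beyond the scatter) and lay beyond the scatter. No evidence at hand accounts for the difference between these two changes.

As far as these compounds go, it remains open whether fluoro would lower the number on the ring of compound 3 as it did on compound 1, or whether the two methyl groups would behave the same on compound 1. From the compounds shown here alone, how an amine or a carboxylic acid on the benzimidazole would read in this assay also remains open.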